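Trifluoromethyl for iodo on the sulfonamide ring

The source may hold more compounds than are shown below. What is called first, only, known or untested is meant among the compounds shown, and "the series" means these compounds.

Measured compounds:
compound 1, `CC(C)(C)c1ccc(CCC(=S)NCc2ccc(NS(C)(=O)=O)c(F)c2)cc1`, 40 nM
compound 2, `CC(C)(C)c1ccc(CCC(=S)NCc2ccc(NS(C)(=O)=O)c(Cl)c2)cc1`, 96 nM
compound 3, `CC(C)(C)c1ccc(CCC(=S)NCc2ccc(NS(C)(=O)=O)c(I)c2)cc1`, 300 nM

In a functional assay for antagonist activity at transient receptor potential cation channel subfamily V member 1 (Rattus norvegicus) (a lower number here means a stronger inhibitor, a higher number a weaker inhibitor), compound 3 gives the highest of the three numbers, the others reading lower by a 3.1-fold higher number from compound 2 to compound 3 (0.49 log units; beyond the scatter) and by a 7.5-fold higher number from compound 1 to compound 3 (0.88 log units; beyond the scatter). Compound 4 is `CC(C)(C)c1ccc(CCC(=S)NCc2ccc(NS(C)(=O)=O)c(C(F)(F)F)c2)cc1`; the change from compound 3 is trifluoromethyl in place of iodo on an aromatic carbon. Among the compounds with values here, none of the measured steps introduces a trifluoromethyl group; the steps of a 2.4-fold higher number from compound 1 to compound 2 (0.38 log units; beyond the scatter) and a 3.1-fold higher number from compound 2 to compound 3 (0.49 log units; beyond the scatter) only show each halogen exchange at this position shifting the number, all in one direction. The step of a 1.5-fold lower number from compound 3 to compound 4 (0.18 log units; within the scatter) is therefore expected to stay modest, and compound 4 is estimated at 200 nM, within 70 nM to 600 nM, in this assay.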

Compound 4, half-maximal inhibitory concentration: 940 nM
Compound 4: middle estimate off by 4.7-fold (0.67 log units), on the low side; the measured number lies above the stated range.
By their numbers in this assay, from the lowest: compound 1; then compound 2; then compound 3; then compound 4.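

In this assay trifluoromethyl, ortho to a methanesulfonamido group, continues the upward run instead of reversing it, with a 3.1-fold higher number from compound 3 to compound 4 (0.50 log units; beyond the scatter) and a 9.8-fold higher number from compound 2 to compound 4 (0.99 log units; beyond the scatter) and a 24-fold higher number from compound 1 to compound 4 (1.37 log units; beyond the scatter) as the only large step shown. Among these four compounds the numbers rise from fluoro through chloro and iodo to trifluoromethyl, and none goes against that order. Nothing given here accounts for this order. From the compounds shown here alone, what remains open is how a methyl, methoxy or nitrile group would read at this position. Going by these compounds, it is also open whether a plain hydrogen there would give a lower number than fluoro.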